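The compounds below may be only part of what the source reports. "The series", "measured", "known", "first", "only" and "open" are said of these compounds alone.

In a functional assay on the whole organism for inhibition, with Scenedesmus acutus as the target (on this read-out higher numbers stand for weaker inhibition and lower numbers for stronger inhibition), compound 3 `CCC(C)OC(=O)c1cc(N2C(=O)C3=C(CCCC3)C2=O)ccc1Cl` gives 1100 nM, the lowest of the three numbers measured. Compound 1 `COC(=O)c1cc(N2C(=O)C3=C(CCCC3)C2=O)ccc1Cl` gives 1780 nM, and the step of a 1.6-fold lower number from compound 1 to compound 3 (0.21 log units; within the scatter) does not reach beyond the scatter. Compound 2 `CCCCOC(=O)c1cc(N2C(=O)C3=C(CCCC3)C2=O)ccc1Cl` gives 6310 nM; the step of a 5.7-fold lower number from compound 2 to compound 3 (0.76 log units; beyond the scatter) is clear, as is a 3.5-fold higher number from compound 1 to compound 2 (0.55 log units; beyond the scatter). Compound 4 `C#CCOc1cc(N2C(=O)C3=C(CCCC3)C2=O)ccc1Cl` carries propargyloxy in place of sec-butoxycarbonyl on an aromatic carbon. Going by the values given here, every measured step varies only the alkyl on the oxygen of the ester, and none removes the ester itself, so no measured step bears directly on this change; the step of a 1.8-fold higher number from compound 3 to compound 4 (0.26 log units; within the scatter) is expected to stay within the spread of the three numbers, in no firm direction. Compound 4 is therefore estimated at 2000 nM, with a range from 500 nM to 8000 nM.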

Compound 4, half-maximal inhibitory concentration: 100 nM
Estimate against measurement, compound 4: 20-fold (1.30 log units) above; measured number below the stated range.
By their numbers in this assay, from the lowest: compound 4; then compounds 3 and 1 (each within the scatter of the next); then compound 2.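

In this assay, replacing the ester on the aromatic carbon ortho to a chloro group with propargyloxy gives an 11-fold lower number from compound 3 to compound 4 (1.04 log units; beyond the scatter) and an 18-fold lower number from compound 1 to compound 4 (1.25 log units; beyond the scatter) and a 63-fold lower number from compound 2 to compound 4 (1.80 log units; beyond the scatter) as the three new steps. Changes of the alkyl on the ester moved the number less, and a low number at this position does not depend on the ester carbonyl. Nothing available accounts for the size of these steps.

As far as these compounds go, whether the gain belongs to the triple bond or to the ether oxygen stays open, and a propoxy or allyloxy group would separate the two. From the compounds shown here alone, how a carboxylic acid would compare at this position also stays open.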